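Replacing pyridin-3-yl on the shared core

The compounds below may be only part of what the source reports. "The series", "measured", "known", "first", "only" and "open" are said of these compounds alone.

In a functional assay on HCT-15 cells (Homo sapiens) for cytotoxicity, in the presence of a further agent that is not named here (on this read-out higher numbers stand for weaker inhibition and lower numbers for stronger inhibition), compound 1 (`Clc1ccc(-c2cc(-c3ccsc3)nc(-c3ccccc3Cl)c2)o1`) gives 4570 nM and compound 2 (`Cc1ccccc1-c1cc(-c2ccc(Cl)o2)cc(-c2ccsc2)n1`) gives 4630 nM as measured values. The exchange of chloro for methyl amounts to a 1.0-fold higher number from compound 1 to compound 2 (0.01 log units; within the scatter) and so separates nothing. Compound 3 (`Clc1ccc(-c2cc(-c3cccnc3)nc(-c3ccsc3)c2)o1`) gives > 50000 nM which is a limit and not a number.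

Within the data shown here, compound 4 (`Cc1ccc(-c2cc(-c3ccc(Cl)o3)cc(-c3ccsc3)n2)o1`) has no measurement yet. It carries 5-methylfuran-2-yl in place of pyridin-3-yl on an aromatic carbon next to the ring nitrogen, and the counted difference is 5-methylfuran-2-yl in place of pyridin-3-yl on an aromatic carbon in all.

Among the measured compounds shown here, the steps that bear on this are an at least 10-fold higher number from compound 1 to compound 3 (1.03 log units; beyond the scatter) for pyridin-3-yl in place of 2-chlorophenyl and an at least 10-fold higher number from compound 2 to compound 3 (1.03 log units; beyond the scatter) for pyridin-3-yl in place of 2-methylphenyl and both are large. Read in reverse, they point to a large move toward lower numbers, though neither tests a furan at this place. The expected move is an at least 10-fold lower number from compound 3 to compound 4 (1.00 log units; beyond the scatter) on this reading. For compound 4 the estimate is 5000 nM with an expected range from 1500 nM to 20000 nM in this assay for now.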

Compound 4, half-maximal inhibitory concentration: > 50000 nM
Compound 4 ended at the assay's limit; the forecaster's own chance of this, stated with the estimate: 15%; middle value at least 10-fold (1.00 log units) from the limit.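

In this assay, 5-methylfuran-2-yl at this position does not keep what 2-chlorophenyl and 2-methylphenyl give, with an at least 10-fold higher number from compound 1 to compound 4 (1.03 log units; beyond the scatter) and an at least 10-fold higher number from compound 2 to compound 4 (1.03 log units; beyond the scatter). The loss seen with pyridin-3-yl is thus not confined to that group: a five-membered aromatic ring with an oxygen in place of a six-membered one with a nitrogen ends the same way, and among the compounds shown only the two substituted phenyl groups give measured values. The step between compound 3 and compound 4 cannot be read, since each value is a limit and not a number: the limit of > 50000 nM in this assay, at which 2 of the 4 values shown sit.

On these data alone, whether an unsubstituted phenyl would still give a measured value here remains open. So does the result for a phenyl carrying an amine or a carboxylic acid at this position.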